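The source may report more compounds than this note shows. Statements on the series, on what has been measured and on what is new or still open speak of the compounds shown alone.

Compound 1 `CCc1cnc(OCC(C)(C)O)c(-c2ccc(S(C)(=O)=O)cc2)c1` gives 1.35 L/kg
Compound 2 `CCCOc1nc(OCC(C)(C)O)c(-c2ccc(S(C)(=O)=O)cc2)cc1CO` gives 3.05 L/kg

In an ADME assay on the whole organism (Mus musculus, strain C57BL/6J) for pharmacokinetics, with a stated time of 24 h, at a dose of 2 mg/kg by the intravenous route (on this read-out lower numbers stand for narrower distribution and higher numbers for wider distribution into tissues), compound 2 stands highest of the two, and compound 1 lies below it by more than the usual scatter. Compound 3 `CCCCOc1nc(OCC(C)(C)O)c(-c2ccc(S(C)(=O)=O)cc2)cc1CO` departs from compound 2 in one place: methyl in place of hydrogen on a saturated chain carbon, three bonds along the chain from an oxygen on an aromatic ring turns the propyl chain into butyl, with methyl in place of hydrogen on a saturated chain carbon, three bonds along the chain from an oxygen on an aromatic ring. Going by the values given here, no measured pair shows this change, so the expectation rests only on the small size of the change and on compound 2 at 3.05 L/kg as the starting point. The expected 1.1-fold higher number from compound 2 to compound 3 (0.03 log units; within the scatter) is slightly upward and stays within the scatter. Compound 3 is estimated at 3.3 L/kg with an expected range from 1.8 L/kg to 6 L/kg in this assay when measured.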

Compound 3, volume of distribution at steady state: 4.92 L/kg
Compound 3: the middle estimate sits 1.5-fold (0.17 log units) below what was measured; measured number inside the range.
By their numbers in this assay, from the lowest: compound 1; then compounds 2 and 3 (each within the scatter of the next).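

At the position on a saturated chain carbon, three bonds along the chain from an oxygen on an aromatic ring, the change from propyl to butyl now has its first measured reading. In this assay it gives a 1.6-fold higher number from compound 2 to compound 3 (0.21 log units; within the scatter) for methyl in place of hydrogen, so on this one pair the added methyl produces no difference that can be told from the usual scatter. No measurement is at hand that could account for this reading.

Going by these compounds, whether a longer chain than butyl, or a chain ending in an amine or a carboxylic acid, would stay within the scatter of compound 3 remains open. A single pair also leaves open whether the same step would read alike on another core.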